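Methoxycarbonyl to hydroxymethyl: from compound 2 to compound 3

A few compounds are considered here, and "the series" means these few. Any claim that something is new, unique, unknown or untested is made for them only; others in the source may bear on it.

In a functional assay on SW1573 cells (Homo sapiens) for antiproliferative activity, read by sulforhodamine B assay, with a stated time of 48 h (a lower number here means a stronger inhibitor of growth, a higher number a weaker inhibitor of growth), compound 1 (`CC(C)(C)[Si](C)(C)O[C@@H]1CCCO[C@@H]1COCC(=O)O`) gives > 100000 nM, which is a limit and not a number. Compound 2 (`COC(=O)CCOC[C@H]1OCCC[C@H]1O[Si](C)(C)C(C)(C)C`) gives > 100000 nM, which is also a limit. Among the compounds with values here, the series so far stands at the limit of > 100000 nM in this assay, at which 2 of the 2 values shown sit.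

Compound 3 (`CC(C)(C)[Si](C)(C)O[C@@H]1CCCO[C@@H]1COCCCO`) differs from compound 2 by hydroxymethyl in place of methoxycarbonyl on a saturated chain carbon, two bonds along the chain from an oxygen on a saturated carbon.

Within the data shown here, the one measured step bearing on this is a step that the two limits leave unreadable from compound 1 to compound 2. It offers no size to carry over, and it concerns a different change at the same chain end. No clear gain in this assay is therefore expected, and a reading at the limit is the likely outcome. The estimated step is a number no higher from compound 2 to compound 3 (the limit leaves the size open). For compound 3 the expected value is 100000 nM, with an estimated range of 40000 nM to 200000 nM.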

Compound 3, concentration for 50% growth inhibition: > 100000 nM
Compound 3 ended at the assay's limit; the forecaster's own chance of this, stated with the estimate: 80%; the middle value sits exactly at the limit.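

No step can be read among compound 1, compound 2 and compound 3, since each stands at a limit and not at a number: the limit of > 100000 nM in this assay, at which 3 of the 3 values shown sit.
In this assay the compounds shown leave open whether any change at this chain end gives a readable value.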